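The source may hold more compounds than are shown below. What is called first, only, known or untested is meant among the compounds shown, and "the series" means these compounds.

Working notes on the series. Compound 1 `c1ccc(-c2cn3ccnc3c(-c3ccc4ncn(C5CCCCC5)c4c3)n2)cc1` and compound 2 `Clc1ccc(-c2cn3ccnc3c(-c3ccc4ncn(C5CCCCC5)c4c3)n2)cc1` share one core and differ only on the phenyl ring. In a functional assay on IGROV-1 cells (Homo sapiens) for inhibition, read by sulforhodamine B assay, with a stated time of 48 h, tested at 10 uM (a higher number here means more inhibition at the concentration tested (going by the name of the read-out), a lower number less inhibition), compound 1 gives 12%, and in this assay compound 2 gives 7.84%. The step of a number 4.2 percentage points lower from compound 1 to compound 2 (within the scatter) comes with chloro in place of hydrogen on an aromatic carbon and stays within the scatter. For the measured compounds named here, compound 2 thus stands at the lowest of the two numbers measured so far, but its gap to compound 1 is within the scatter, so no order between the two is claimed.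

Compound 3 `Brc1ccc(-c2cn3ccnc3c(-c3ccc4ncn(C5CCCCC5)c4c3)n2)cc1` is the next member, differing from compound 2 by bromo in place of chloro on an aromatic carbon. Going by the values given here, only one measured step touches this ring, a number 4.2 percentage points lower from compound 1 to compound 2 (within the scatter), and it was within the scatter. Among the compounds with values here, with no other step to draw on, the change from chloro to bromo at the same place is expected to give a step of no size beyond the scatter, a number 1.2 percentage points higher from compound 2 to compound 3 (within the scatter). Compound 3 is therefore estimated at 9% in this assay, with an expected range from 0% to 20%.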

Compound 3, a percentage reported as inhibition, at one concentration (the size of the read-out at that concentration, not a potency): 9.4%
Estimate against measurement, compound 3: 0.4 percentage points below; the measured number falls inside the stated range.
By their numbers in this assay, from the lowest: compounds 2, 3 and 1 (each within the scatter of the next).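

In this assay, the change from 4-chlorophenyl to 4-bromophenyl gives a number 1.6 percentage points higher from compound 2 to compound 3 (within the scatter) and so adds a second halogen swap at this place, para to a large group, that leaves the read-out inside the scatter. Bromo in place of hydrogen at the same carbon gives a number 2.6 percentage points lower from compound 1 to compound 3 (within the scatter) and therefore joins chloro in place of hydrogen, which gave a number 4.2 percentage points lower from compound 1 to compound 2 (within the scatter) as a second halogen step from the unsubstituted phenyl that stays within the scatter, so hydrogen, chloro and bromo at this place cannot be put in any order. Nothing measured here offers an explanation for these small steps.

As far as these compounds go, whether an amine or a carboxylic acid at this place would give a step beyond the scatter remains open, and the same holds for a longer chain such as a butoxy group. From the compounds shown here alone, the three compounds also share the rest of their structure, so what a change elsewhere on the core of compound 1 would do to the read-out in this assay stays open as well.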